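Lengthening the amide chain on compound 3

This account rests on a few compounds, and the source may have more. Where it says the series, first, only, none or still open, it means among the compounds named here.

Of the compounds shown here, three have been measured in an assay on isolated protein for inhibition of Flap endonuclease 1 (Homo sapiens); a lower number here means a stronger inhibitor, a higher number a weaker inhibitor. Compound 1 `CC(=O)Nc1ccc2c(=O)n(O)c(=O)[nH]c2c1` gives 2100 nM in this assay. Compound 2 `O=c1cc(-c2ccccc2)[nH]c(=O)n1O` gives 630 nM in this assay. Compound 3 `CCCNC(=O)c1nc(-c2cccs2)[nH]c(=O)c1O` gives 4200 nM in this assay. The number for compound 3 is the largest of the three, but its gap to compound 1 is within the usual scatter, so these two cannot be told apart; its gap to compound 2 lies beyond the scatter. Among the measured compounds shown here, no single-point step between measured compounds is available, so nothing measured tells how a change of this kind moves the read-out.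

Compound 4 `CC(C)CCNC(=O)c1nc(-c2cccs2)[nH]c(=O)c1O` has not been measured. It differs from compound 3 in one place: isopropyl in place of methyl on a saturated chain carbon, two bonds along the chain from an amide-type nitrogen. Compound 1 and compound 2 share no such chain and offer no guidance on it. Compound 4 is therefore expected to stay near compound 3, with the step of a 1.2-fold lower number from compound 3 to compound 4 (0.08 log units; within the scatter) expected to lie within the scatter rather than in either clear direction. On that basis compound 4 is estimated to give 3500 nM in this assay, with a range from 1200 nM to 10000 nM.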

Compound 4, half-maximal inhibitory concentration: 3500 nM
Estimate against measurement, compound 4: no gap at the digits printed; the measured number falls inside the stated range.
By their numbers in this assay, from the lowest: compound 2; then compounds 1, 4 and 3 (each within the scatter of the next).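

In this assay, isopropyl in place of methyl on a saturated chain carbon, two bonds along the chain from an amide-type nitrogen, gives a 1.2-fold lower number from compound 3 to compound 4 (0.08 log units; within the scatter), the only single-point step among the compounds shown. Among the compounds shown here, this gives the first measured reading at this position: the propyl chain of compound 3 and the isopentyl chain of compound 4 cannot be told apart in this assay, so this change to the amide chain produces no detectable shift in the read-out. No measurement of any other property of these compounds bears on this result, so the step can be reported but not explained.

What the compounds shown leave open is whether the same flat response holds for groups of another kind on this chain, such as a longer chain like octyl, a phenyl ring, an amine or a carboxylic acid. On these data alone, with one step at one position, it also remains open whether the read-out at this place can move clearly in either direction, or whether it stays within the scatter whatever group is placed there.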